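Naphthalen-2-yl for Methoxyphenyl: Expected Gain in Growth Inhibition

A few compounds are considered here, and "the series" means these few. Any claim that something is new, unique, unknown or untested is made for them only; others in the source may bear on it.

In a functional assay on cells (Cancer cell lines, Homo sapiens) for cytotoxicity, read by sulforhodamine B assay, with a stated time of 48 h (a lower number here means a stronger inhibitor of growth, a higher number a weaker inhibitor of growth), compound 2 `COc1ccc(C2=NN(C3=NC(=O)/C(=C4\C(=O)Nc5ccccc54)S3)C(c3ccc(OC)cc3)C2)cc1` gives 100000 nM, the highest number among the three measured compounds. Compound 1 `COc1ccc(C2CC(c3ccccc3)=NN2C2=NC(=O)/C(=C3\C(=O)Nc4ccccc43)S2)cc1` gives 3350 nM and compound 3 `COc1ccc(C2=NN(C3=NC(=O)/C(=C4\C(=O)Nc5ccc(Br)cc54)S3)C(c3ccc(OC)cc3)C2)cc1` gives 710 nM. The step of a 30-fold higher number from compound 1 to compound 2 (1.47 log units; beyond the scatter) came with methoxy in place of hydrogen on an aromatic carbon, and the step of a 140-fold lower number from compound 2 to compound 3 (2.15 log units; beyond the scatter) with bromo in place of hydrogen on another aromatic carbon. Compound 4 `COc1ccc(C2CC(c3ccc4ccccc4c3)=NN2C2=NC(=O)/C(=C3\C(=O)Nc4ccccc43)S2)cc1` differs from compound 2 by naphthalen-2-yl in place of 4-methoxyphenyl on a carbon with a double bond to nitrogen. The methoxy disappears with this change, and because compound 1 without it gives 3350 nM, a large downward step is expected, a 33-fold lower number from compound 2 to compound 4 (1.52 log units; beyond the scatter). The bromo step sits elsewhere and offers no direct guidance. Compound 4 is therefore estimated at 3000 nM, with a range from 600 nM to 15000 nM.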

Compound 4, concentration for total growth inhibition: 2470 nM
The estimate for compound 4 lay 1.2-fold (0.08 log units) above the measured number, within the range that was stated.
By their numbers in this assay, from the lowest: compound 3; then compounds 4 and 1 (each within the scatter of the next); then compound 2.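

In this assay, on the carbon with a double bond to nitrogen, naphthalen-2-yl brings a 40-fold lower number from compound 2 to compound 4 (1.61 log units; beyond the scatter) when it replaces 4-methoxyphenyl, whereas replacing phenyl it brings a 1.4-fold lower number from compound 1 to compound 4 (0.13 log units; within the scatter) and no more. Of the three groups at this position, only 4-methoxyphenyl goes with the high number, and the second aromatic ring of naphthalen-2-yl does not bring one. Nothing measured here accounts for this difference.

Open, from the compounds shown here alone, is how an amine or a carboxylic acid on this carbon would read. Also open, going by these compounds, is whether the bromo of compound 3 would lower the number of compound 4.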